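A few compounds are considered here, and "the series" means these few. Any claim that something is new, unique, unknown or untested is made for them only; others in the source may bear on it.

The measured compounds and their values in a functional assay on the whole organism (strain albino) for inhibition, with Rattus norvegicus as the target, read by paw edema, with a stated time of 4 h, at a dose of 0.28 mmol/kg by the oral route; on this read-out lower numbers stand for less inhibition and higher numbers for more inhibition at the one dose given (going by the name of the read-out):

Compound 1, `C=CCn1c(SC/C(=N/O)c2ccccc2)nnc1-c1ccc(OC)cc1`: 76%
Compound 2, `C=CCn1c(SCC(=O)c2ccccc2)nnc1-c1ccc(OC)cc1`: 67%
Compound 3, `CCn1c(SC/C(=N/O)c2ccccc2)nnc1-c1ccc(OC)c(OC)c1`: 82%

Compound 1 and compound 2 share a core and differ in one place: a group of 8 heavy atoms (7 carbon, 1 oxygen; one six-membered aromatic ring of carbon only) in place of a group of 9 heavy atoms (7 carbon, 1 nitrogen, 1 oxygen; one six-membered aromatic ring of carbon only), on a saturated chain carbon bound to a sulfur. This change gave a number 9 percentage points lower from compound 1 to compound 2 (within the scatter), so on its own it did not move the read-out clearly. Compound 3 carries a different core; the difference between the two cores is not broken down here. Compound 3 and compound 1 lie within the scatter of each other, while compound 2 sits beyond the scatter below compound 3.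

Compound 4, `CCn1c(SCC(=O)c2ccccc2)nnc1-c1ccc(OC)c(OC)c1`, is not yet measured. It arises from compound 3 by the same change seen between compound 1 and compound 2: a group of 8 heavy atoms (7 carbon, 1 oxygen; one six-membered aromatic ring of carbon only) in place of a group of 9 heavy atoms (7 carbon, 1 nitrogen, 1 oxygen; one six-membered aromatic ring of carbon only), on a saturated chain carbon bound to a sulfur. Because the earlier step was a number 9 percentage points lower from compound 1 to compound 2 (within the scatter), a step of similar size is expected here, estimated as a number 9 percentage points lower from compound 3 to compound 4 (within the scatter) in this assay. Compound 4 is therefore expected to give about 73%, most likely between 62% and 83%.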

Compound 4, a percentage reported as inhibition, in the whole organism at one dose (the size of the read-out at that dose, not a potency): 73%
The estimate for compound 4 equals the measured number at the digits printed, and the stated range covers the measured number.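

In this assay, putting benzoyl in place of the nitrogen-bearing group gave a number 9 percentage points lower from compound 3 to compound 4 (within the scatter), so on the core of compound 3 this change again did not clearly move the read-out. Among these compounds, the step has the same size as the one seen on the core of compound 1, which means that in these two pairs the change carried over from one core to the other without any visible difference: the same change on two cores in this assay, a number 9 percentage points lower (within the scatter) from compound 1 to compound 2 and a number 9 percentage points lower (within the scatter) from compound 3 to compound 4, 0 percentage points apart, within the scatter of two such steps This does not show that the change has no effect at all or that it would behave the same way on further cores: both steps lie within the scatter, only two cores are compared, and a single dose gives no potency.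

The compounds shown leave open how the read-out would respond to an amine or a carboxylic acid on the saturated chain carbon bound to a sulfur. They also leave open whether a longer chain at that place would give a clearer step.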